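A few compounds are considered here, and "the series" means these few. Any claim that something is new, unique, unknown or untested is made for them only; others in the source may bear on it.

Values in a physicochemical assay for lipophilicity, at pH 7.4; on this read-out lower numbers stand for lower lipophilicity and higher numbers for higher lipophilicity:
- compound 1 `CCOc1ccc2c(c1)C=CN(C)C(=O)C2C`: 5
- compound 2 `C[C@H]1C(=O)N(C)C=Cc2cc(OC(CO)CO)ccc21`: 1.3
- compound 3 `C[C@H]1C(=O)N(C)C=Cc2cc(CC3CCOCC3)ccc21`: 5.4

Compound 3, at 5.4, has the highest number of the three. Its gaps to compound 1 and compound 2 both lie beyond the scatter.

The next structure is compound 4 `CCS(=O)(=O)c1ccc2c(c1)C=CN(C)C(=O)[C@@H]2C`, still unmeasured, with ethylsulfonyl in place of (oxan-4-yl)methyl on an aromatic carbon.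

Among the compounds with values here, only one measured step bears on this change: a number 4.10 log units higher from compound 2 to compound 3 (beyond the scatter). That step is large, and in it (oxan-4-yl)methyl replaces 2-hydroxy-1-(hydroxymethyl)ethoxy at the same kind of place. Within the data shown here, no measured compound carries ethylsulfonyl, so this single step is weak guidance and the range has to stay wide. In this assay, a large step downward is expected, though smaller than the measured one. The estimated change is a number 2.20 log units lower from compound 3 to compound 4 (beyond the scatter). Compound 4 is expected at 3.2, with an estimated range from 2.4 to 4.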

Compound 4, distribution coefficient: 3.1
Estimate against measurement, compound 4: 0.10 log units above, within the range that was stated.
By their numbers in this assay, from the lowest: compound 2; then compound 4; then compound 1; then compound 3.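

At this aromatic carbon, this assay moves by a large amount even when neither group carries a hydrogen-bond donor: ethylsulfonyl in place of (oxan-4-yl)methyl gives a number 2.30 log units lower from compound 3 to compound 4 (beyond the scatter) on the shared core. Set against 2-hydroxy-1-(hydroxymethyl)ethoxy, ethylsulfonyl gives a number 1.80 log units higher from compound 2 to compound 4 (beyond the scatter) and so takes an intermediate place, showing that the position separates three groups rather than only the two extremes seen earlier. No evidence is available on what underlies either shift.

The change from (oxan-4-yl)methyl to ethylsulfonyl removes the ring and brings in the sulfonyl at once, so the two cannot be told apart here. On these data alone, it also remains open how a methylsulfonyl group, a longer sulfonyl chain, an amine or a carboxylic acid at this carbon would fall in this order.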